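This account rests on a few compounds, and the source may have more. Where it says the series, first, only, none or still open, it means among the compounds named here.

Measured compounds:
compound 1 `CCC(CC)n1c(-c2ccc(OCc3c(-c4c(Cl)cccc4Cl)noc3C(C)C)cc2)nc2ccc(C(=O)O)cc21` — in an assay on Huh-7 cells for agonist activity at Bile acid receptor (Homo sapiens), read by a luciferase reporter (a lower number here means that less compound is needed, a higher number that more compound is needed for the effect), compound 1 gives 0.8 nM
compound 2 `CC(C)c1onc(-c2c(Cl)cccc2Cl)c1COc1ccc(-c2nc3cc(C(=O)O)ccc3n2C)cc1` — in this assay compound 2 gives 25.8 nM
compound 3 `CC(C)c1onc(-c2c(Cl)cccc2Cl)c1COc1ccc(-c2nc3ccc(C(=O)O)cc3n2CC(C)(C)C)cc1` — in this assay compound 3 gives 13 nM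

Compound 3 stands second highest of the three numbers; compound 2 lies within the scatter of it, while compound 1 lies far below it. Compound 4 `CCCC(CCC)n1c(-c2ccc(OCc3c(-c4c(Cl)cccc4Cl)noc3C(C)C)cc2)nc2ccc(C(=O)O)cc21` differs from compound 3 by 1-propylbutyl in place of neopentyl on an aromatic nitrogen. Within the data shown here, the one measured step at this position is a 16-fold higher number from compound 1 to compound 3 (1.21 log units; beyond the scatter), a large change from one alkyl group to another on the same nitrogen. The 1-propylbutyl of compound 4 is closer in kind to the pentan-3-yl of compound 1 than to the neopentyl of compound 3, so a step back toward the number of compound 1 is expected, a 5.2-fold lower number from compound 3 to compound 4 (0.72 log units; beyond the scatter). Compound 4 is therefore estimated at 2.5 nM in this assay, within 0.6 nM to 10 nM.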

Compound 4, half-maximal effective concentration: 1.8 nM
Estimate against measurement, compound 4: 1.4-fold (0.14 log units) above; low and high end bracket the measured number.
By their numbers in this assay, from the lowest: compound 1; then compound 4; then compounds 3 and 2 (each within the scatter of the next).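

In this assay, 1-propylbutyl on this aromatic nitrogen gives a much lower number than neopentyl (a 7.2-fold lower number from compound 3 to compound 4 (0.86 log units; beyond the scatter)), so the larger of these two groups is well accepted here. It does not quite match pentan-3-yl, however (a 2.3-fold higher number from compound 1 to compound 4 (0.35 log units; beyond the scatter)), so a small difference between two similar alkyl groups still registers at this position. No available evidence bears on the reason for either step. The compounds shown leave open how a cyclohexyl ring, a phenyl ring or an amine-bearing chain on this nitrogen would fare.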